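Swapping Halogens on a Pyridyl Sulfonamide

The source may hold more compounds than are shown below. What is called first, only, known or untested is meant among the compounds shown, and "the series" means these compounds.

Of the compounds shown here, three sharing one core have been tested in a functional assay on DLD-1 cells (Homo sapiens) for antiproliferative activity, read by CellTiter-Glo, with a stated time of 72 h; on this read-out higher numbers stand for weaker inhibition and lower numbers for stronger inhibition. Compound 1 `CC1CCN(C2CCN(S(=O)(=O)c3cccnc3)CC2)CC1` gives 2400 nM. Compound 2 `Cc1cccc(S(=O)(=O)N2CCC(N3CCC(C)CC3)CC2)c1` gives 25 nM. For compound 3 `CC1CCN(C2CCN(S(=O)(=O)c3cccnc3F)CC2)CC1` the assay reports only a limit, > 5000 nM, namely (the limit of > 5000 nM in this assay, at which 1 of the 3 values shown sits). Compound 3 therefore stands at the weak end of the three, with no exact number of its own.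

Among the measured steps, a 96-fold lower number from compound 1 to compound 2 (1.98 log units; beyond the scatter), whereas an at least 2.0-fold higher number from compound 1 to compound 3 (0.31 log units; beyond the scatter) and an at least 200-fold higher number from compound 2 to compound 3 (2.30 log units; beyond the scatter).

Compound 4 `CC1CCN(C2CCN(S(=O)(=O)c3ccc(Cl)nc3)CC2)CC1` differs from compound 3 by a single change: 6-chloropyridin-3-yl in place of 2-fluoropyridin-3-yl on a sulfonyl sulfur. Among the measured compounds shown here, no measured step exchanges one halogen on the pyridine for another, so the bearing of earlier steps is indirect. The step of an at least 2.0-fold higher number from compound 1 to compound 3 (0.31 log units; beyond the scatter) shows that a halogen added to the pyridin-3-yl of compound 1 raised the number at least modestly; a different halogen at a different carbon is expected to land compound 4 somewhere between compound 1 and the limit, so the estimate for compound 4 is 3500 nM, within 900 nM to 12000 nM, meaning an expected step of an at least 1.4-fold lower number from compound 3 to compound 4 (0.15 log units; that floor lies within the scatter).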

Compound 4, half-maximal inhibitory concentration: 3700 nM
Compound 4: the middle estimate sits 1.1-fold (0.02 log units) below what was measured; measured number inside the range.
By their numbers in this assay, from the lowest: compound 2; then compounds 1 and 4 (each within the scatter of the next). At a limit, above all of these: compound 3.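

In this assay, chloro in place of hydrogen on the pyridin-3-yl of compound 1 gives a step within the scatter, a 1.5-fold higher number from compound 1 to compound 4 (0.19 log units; within the scatter), so this halogen on this carbon costs no measurable activity. The 6-chloropyridin-3-yl still falls far short of the 3-methylphenyl on the sulfonyl sulfur, with a 150-fold higher number from compound 2 to compound 4 (2.17 log units; beyond the scatter). The exchange of halogens can be read only as a floor, an at least 1.3-fold lower number from compound 3 to compound 4 (0.13 log units; that floor lies within the scatter), because compound 3 carries no exact number: the limit of > 5000 nM in this assay, at which 1 of the 4 values shown sits.

From the compounds shown here alone, whether an amine or a methoxy group in place of the chloro would narrow the gap to compound 2 remains open. So does how fluoro would behave on the carbon that carries chloro in compound 4, which would separate the choice of halogen from its place on the ring.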